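This account rests on a few compounds, and the source may have more. Where it says the series, first, only, none or still open, it means among the compounds named here.

Compound 1 `CCCC(=O)Nc1ccc(S(=O)(=O)Oc2ccccc2I)cc1` and compound 2 `O=C(CCl)Nc1ccc(S(=O)(=O)Oc2ccccc2I)cc1` share a core and differ in one place, (chloro in place of ethyl on a saturated chain carbon bound to a carbonyl carbon). In a functional assay on HT-1080 cells (Homo sapiens) for antiproliferative activity, read by sulforhodamine B assay, with a stated time of 48 h (a lower number here means a stronger inhibitor, a higher number a weaker inhibitor), compound 1 gives 2000 nM, while compound 2 gives 600 nM, so the change brought a 3.3-fold lower number from compound 1 to compound 2 (0.52 log units; beyond the scatter). Compound 3 `CCCCCNC(=O)Nc1ccc(S(=O)(=O)Oc2ccccc2C(C)C)cc1` has a different core; how its core differs from that of compound 1 is not broken down here. In this assay compound 3 gives 4700 nM. Compound 4 `CC(C)c1ccccc1OS(=O)(=O)c1ccc(NC(=O)NCCCCl)cc1` differs from compound 3 by chloro in place of ethyl on a saturated chain carbon, three bonds along the chain from an amide-type nitrogen. Among the compounds with values here, this is the same kind of change as the one from compound 1 to compound 2, but not the same: there the place was on a saturated chain carbon bound to a carbonyl carbon, here it is three bonds along the chain from an amide-type nitrogen. Within the data shown here, for compound 4 a step of a 2.4-fold lower number from compound 3 to compound 4 (0.37 log units; beyond the scatter) is expected, somewhat smaller than the earlier one because the place differs and only the single step of a 3.3-fold lower number from compound 1 to compound 2 (0.52 log units; beyond the scatter) supports it, giving an estimated 2000 nM with a range from 700 nM to 6000 nM.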

Compound 4, half-maximal inhibitory concentration: 2700 nM
Compound 4: the middle estimate sits 1.4-fold (0.13 log units) below what was measured; low and high end bracket the measured number.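

In this assay, chloro in place of ethyl on the second core gives a 1.7-fold lower number from compound 3 to compound 4 (0.24 log units; within the scatter), a step too small to separate from repeat measurements. Set side by side, the two steps do not disagree: the same change on two cores in this assay, a 3.3-fold lower number (0.52 log units; beyond the scatter) from compound 1 to compound 2 and a 1.7-fold lower number (0.24 log units; within the scatter) from compound 3 to compound 4, 1.9-fold (0.28 log units) apart, within the scatter of two such steps. So the change can be carried from one core to the other without a detectable difference in step size, but this does not prove that the steps are equal, since each core offers only one pair and the change sits at a different place on each.

The compounds shown leave open how an amine, a hydroxyl group or a longer chain in place of chloro would fare. They also leave open whether the step holds on any further core.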